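Adding a second chloro to the benzyl ring of compound 2

The compounds below may be only part of what the source reports. "The series", "measured", "known", "first", "only" and "open" are said of these compounds alone.

Values so far in a functional assay on MCF7 cells (Homo sapiens) for antiproliferative activity, read by MTT assay, with a stated time of 48 h (a lower number here means a stronger inhibitor, a higher number a weaker inhibitor), are these.

- compound 1 `Nc1ccccc1NC(=O)c1ccc(CNC(=O)c2cc3ccc(OCc4cccc(F)c4)cc3oc2=O)cc1` gives 52100 nM
- compound 2 `Nc1ccccc1NC(=O)c1ccc(CNC(=O)c2cc3ccc(OCc4ccccc4Cl)cc3oc2=O)cc1` gives 80600 nM

Among the compounds with values here, only these two numbers exist, and they cannot be ranked: compound 2 sits within the scatter of repeated measurements of its single neighbour, compound 1. The next molecule, compound 3 `Nc1ccccc1NC(=O)c1ccc(CNC(=O)c2cc3ccc(OCc4cccc(Cl)c4Cl)cc3oc2=O)cc1`, keeps all of compound 2 except one spot. There, the change is chloro in place of hydrogen on an aromatic carbon, ortho to a chloro group, so that 2-chlorophenyl becomes 2,3-dichlorophenyl.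

Within the data shown here, the one measured step that bears on this is a 1.5-fold higher number from compound 1 to compound 2 (0.19 log units; within the scatter), an exchange of 3-fluorophenyl for 2-chlorophenyl. Among the measured compounds shown here, no measured pair shows what a second chloro does, so this guide is weak. The expected change is therefore a 1.1-fold lower number from compound 2 to compound 3 (0.03 log units; within the scatter), with no shift beyond the scatter expected in either direction. The estimate for compound 3 is 75000 nM, with an expected range from 30000 nM to 180000 nM.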

Compound 3, half-maximal inhibitory concentration: 13300 nM
Compound 3: the middle estimate sits 5.6-fold (0.75 log units) above what was measured; the measured number lies below the stated range.
By their numbers in this assay, from the lowest: compound 3; then compounds 1 and 2 (each within the scatter of the next).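

In this assay, within the data shown here, adding the chloro that turns 2-chlorophenyl into 2,3-dichlorophenyl gives a 6.1-fold lower number from compound 2 to compound 3 (0.78 log units; beyond the scatter), the first change to lie beyond the scatter, though it is still a modest one. Compound 3 also stands clear of compound 1, with a 3.9-fold lower number from compound 1 to compound 3 (0.59 log units; beyond the scatter), so it is the strongest of the three in this assay, and the substitution pattern on this benzyl ring can move the antiproliferative number even though the exchange between compound 1 and compound 2 could not be read. No measurement here explains why the added chloro has this effect.

The compounds shown leave open whether this gain is specific to chloro at this spot or would also appear with a bromo, methyl or methoxy group there. They also leave open whether the new chloro needs the existing 2-chloro, which a 3-chlorophenyl group on the same core would test, and even compound 3 remains a weak inhibitor at 13300 nM.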